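Nitro removal on a cytotoxic quinone-indole series

This account rests on a few compounds, and the source may have more. Where it says the series, first, only, none or still open, it means among the compounds named here.

Measured compounds:
compound 1, `O=C1C(O)=C(C(c2ccc([N+](=O)[O-])cc2)c2c[nH]c3ccccc23)C(=O)c2ccccc21`, 14800 nM
compound 2, `O=C1C(O)=C(C(c2ccc([N+](=O)[O-])cc2)c2c(-c3ccccc3)[nH]c3ccccc23)C(=O)c2ccccc21`, 6770 nM
compound 3, `COc1cccc(C(C2=C(O)C(=O)c3ccccc3C2=O)c2c[nH]c3ccccc23)c1`, 25600 nM

These three compounds share one core and have been tested in a functional assay on HeLa cells (Homo sapiens) for cytotoxicity, read by MTT assay, with a stated time of 48 h; a lower number here means a stronger inhibitor, a higher number a weaker inhibitor. Compound 2 gives the lowest number of the three. The step of a 2.2-fold lower number from compound 1 to compound 2 (0.34 log units; beyond the scatter) lies beyond the scatter, so compound 2 is a stronger inhibitor than compound 1. Compound 3 sits furthest from compound 2, and its number is also higher than that of compound 1, though the step of a 1.7-fold higher number from compound 1 to compound 3 (0.24 log units; within the scatter) stays within the scatter.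

Compound 4, `O=C1C(O)=C(C(c2ccccc2)c2c(-c3ccccc3)[nH]c3ccccc23)C(=O)c2ccccc21`, has not yet been measured. It differs from compound 2 in one place: hydrogen in place of nitro on an aromatic carbon. Among the compounds with values here, no measured step removes a nitro group alone. Within the data shown here, the only step that touches the same ring is a 1.7-fold higher number from compound 1 to compound 3 (0.24 log units; within the scatter), where the whole group on the saturated chain carbon was exchanged and the number moved only within the scatter. On that basis a small step is expected from compound 2 to compound 4, a 1.4-fold higher number from compound 2 to compound 4 (0.15 log units; within the scatter), in the direction of a somewhat higher number but not beyond the scatter. Compound 4 is therefore estimated at 9500 nM, with a range from 3500 nM to 25000 nM.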

Compound 4, half-maximal inhibitory concentration: 18800 nM
Compound 4: the middle estimate sits 2.0-fold (0.30 log units) below what was measured; the range from low to high includes it.
By their numbers in this assay, from the lowest: compound 2; then compounds 1, 4 and 3 (each within the scatter of the next).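

In this assay, the change from 4-nitrophenyl to phenyl can now be read on its own, and a 2.8-fold higher number from compound 2 to compound 4 (0.44 log units; beyond the scatter) lies beyond the scatter, so compound 2 is a stronger inhibitor than compound 4. The earlier step on this ring, a 1.7-fold higher number from compound 1 to compound 3 (0.24 log units; within the scatter), exchanged the whole group on the saturated chain carbon and stayed within the scatter, so it could not isolate the nitro group; the new step shows that, with everything else held as in compound 2, this one group on the aromatic carbon, para to a large group, moves the number measurably, though modestly. Nothing available bears on why the number rises when the nitro group leaves, so the step stands as an observation only.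

The compounds shown leave open whether losing the nitro group would give a step of similar size on compound 1, which lacks the phenyl group of compound 2. They also leave open how an amine, a nitrile or a carboxylic acid at this same place would compare with nitro and with hydrogen.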